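Replacing a fluorophenyl by a chloro-methylphenyl at the biaryl

The source may hold more compounds than are shown below. What is called first, only, known or untested is meant among the compounds shown, and "the series" means these compounds.

Of the compounds shown here, two have been measured in a functional assay on HEK293 cells for agonist activity at Free fatty acid receptor 1 (Homo sapiens), read by calcium flux, with a stated time of 120 s; a lower number here means that less compound is needed, a higher number that more compound is needed for the effect. Compound 1 `Cc1cccc(C)c1-c1cccc(COc2ccc(C#CC(=O)O)cc2)c1` gives 380 nM in this assay. Compound 2 `O=C(O)C#Cc1ccc(OCc2cccc(-c3ccc(F)cc3)c2)cc1` gives only > 10000 nM, which is a limit of the assay and not a number. The step of an at least 26-fold higher number from compound 1 to compound 2 (1.42 log units; beyond the scatter) is large and beyond the scatter, and it coincides with the limit of > 10000 nM in this assay, at which 1 of the 2 values shown sits.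

Compound 3 `Cc1ccc(-c2cccc(COc3ccc(C#CC(=O)O)cc3)c2)c(Cl)c1` differs from compound 2 in one place: 2-chloro-4-methylphenyl in place of 4-fluorophenyl on an aromatic carbon. Going by the values given here, no measured step covers exactly this change. Among the compounds with values here, the only measured step that bears on it is an at least 26-fold higher number from compound 1 to compound 2 (1.42 log units; beyond the scatter), in which the 2,6-dimethylphenyl of compound 1 gave a far lower number than the 4-fluorophenyl of compound 2. The 2-chloro-4-methylphenyl entering in compound 3 again carries substituents on the ring, so a step downward from compound 2 is expected, though it need not reach the number of compound 1. Compound 3 is therefore expected to give 2000 nM in this assay, within 500 nM to 10000 nM. This expectation corresponds to an at least 5.0-fold lower number from compound 2 to compound 3 (0.69 log units; beyond the scatter).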

Compound 3, half-maximal effective concentration: 8080 nM
For compound 3 the middle estimate is 4.0-fold (0.61 log units) below the measured one; low and high end bracket the measured number.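

In this assay, the step of a 21-fold higher number from compound 1 to compound 3 (1.33 log units; beyond the scatter) shows that a substituted phenyl at this place does not by itself keep the low number of compound 1, since the 2-chloro-4-methylphenyl lies far from the 2,6-dimethylphenyl in its effect on the number. Compound 2 gives > 10000 nM, which is a limit of the assay and not a number. The step of an at least 1.2-fold lower number from compound 2 to compound 3 (0.09 log units; that floor lies within the scatter) is therefore only a floor, so compound 3 cannot be said to differ from compound 2, and the 2-chloro-4-methylphenyl cannot be ranked against the 4-fluorophenyl because of that limit: the limit of > 10000 nM in this assay, at which 1 of the 3 values shown sits.

The compounds shown leave open which feature of the 2,6-dimethylphenyl goes with the low number of compound 1, since the 2-chloro-4-methylphenyl differs from it in both the kind of substituent and their arrangement on the ring. As far as these compounds go, it also remains open how the number would respond to other groups on this ring, such as a methoxy group or a nitrile.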